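The compounds below may be only part of what the source reports. "The series", "measured", "known", "first", "only" and "open" are said of these compounds alone.

Measured in a functional assay on MCF7 cells (Homo sapiens) for inhibition, read by MTT assay, with a stated time of 72 h; a higher number here means a weaker inhibitor of growth, a lower number a stronger inhibitor of growth:
- compound 1 `CC1(C)CCC[C@]2(C)[C@@H](C=O)C(C=O)=CC[C@@H]12`: 75000 nM
- compound 2 `CC(C)(C)OC(=O)/C=C/C1=CC[C@H]2C(C)(C)CCC[C@]2(C)[C@H]1C=O`: 32000 nM

Compound 2, at 32000 nM, holds the lower of the two numbers, and its gap to compound 1 lies beyond the scatter. Compound 3 `CC(=O)/C=C/C1=CC[C@H]2C(C)(C)CCC[C@]2(C)[C@H]1C=O` is unmeasured and carries methyl in place of tert-butoxy on a carbonyl carbon. Within the data shown here, no measured pair shows this change, so the expectation is weakly grounded. The expected result in this assay is a 1.3-fold lower number from compound 2 to compound 3 (0.11 log units; within the scatter), a small step towards a lower number and none beyond the scatter. For compound 3 the estimated value is 25000 nM, with an expected range of 8000 nM to 70000 nM.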

Compound 3, concentration for 50% growth inhibition: 20000 nM
Compound 3: middle estimate off by 1.3-fold (0.10 log units), on the high side; low and high end bracket the measured number.
By their numbers in this assay, from the lowest: compounds 3 and 2 (each within the scatter of the next); then compound 1.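

In this assay, methyl in place of tert-butoxy on a carbonyl carbon gives a 1.6-fold lower number from compound 2 to compound 3 (0.20 log units; within the scatter), so tert-butoxycarbonyl and acetyl cannot be told apart at this position. On a double-bonded ring carbon, 2-acetylethenyl in place of formyl gives a 3.8-fold lower number from compound 1 to compound 3 (0.57 log units; beyond the scatter), a modest step that is beyond the scatter. Nothing on hand accounts for either step. Open, as far as these compounds go, is how a carboxylic acid or an amide would read on the same carbonyl carbon. Also open, from the compounds shown here alone, is whether a longer chain in place of methyl would read differently.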